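A few compounds are considered here, and "the series" means these few. Any claim that something is new, unique, unknown or untested is made for them only; others in the source may bear on it.

Measured in an ADME assay on microsomes from liver (Homo sapiens) for metabolic stability (a higher number here means faster removal of the compound, a lower number slower removal), so far:
- compound 1, `Cc1cccnc1N(C(=O)N1CCC(c2ccccc2)CC1)[C@@H]1CCCNC1`, gives < 8 mL.min-1.g-1, which is a limit of this assay and not a number
- compound 2, `Cn1ccc2ccnc(N(C(=O)N3CCC(c4ccccc4)CC3)[C@@H]3CCCNC3)c21`, gives 11.8 mL.min-1.g-1
- compound 3, `O=C(CCc1ccc(-n2nnc3cccnc32)cc1)N(c1ncccc1Cl)[C@@H]1CCCNC1`, gives 9.7 mL.min-1.g-1

Compound 2 holds the highest of the two numbers in this assay; compound 3 lies within the scatter of it, and the remaining value is a limit. Compound 4, `Cc1nccnc1N(C(=O)N1CCC(c2ccccc2)CC1)[C@@H]1CCCNC1`, is not yet measured. It differs from compound 2 in one place: a group of 7 heavy atoms (5 carbon, 2 nitrogen; one six-membered aromatic ring with 2 hetero atoms) in place of a group of 10 heavy atoms (8 carbon, 2 nitrogen; one five-membered aromatic ring with 1 hetero atom, one six-membered aromatic ring with 1 hetero atom), on an amide-type nitrogen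

Among the measured compounds shown here, one measured step bears on this change. an at least 1.4-fold higher number from compound 1 to compound 2 (0.16 log units; that floor lies within the scatter): the larger bicyclic group on the amide-type nitrogen came with a number at least that much higher than the floor set by the six-membered ring with one heteroatom, the floor itself being a limit (the limit of < 8 mL.min-1.g-1 in this assay, at which 1 of the 3 values shown sits). The step to compound 4 reverses that enlargement, replacing the bicyclic group with another six-membered aromatic ring, now with two heteroatoms. The number is therefore expected to move back down, by a 1.7-fold lower number from compound 2 to compound 4 (0.23 log units; within the scatter), with a fair chance that only a limit is reported. Compound 4 is estimated at 7 mL.min-1.g-1 in this assay, within 4 mL.min-1.g-1 to 13 mL.min-1.g-1.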

Compound 4, intrinsic clearance in microsomes in the Homo sapiens assay: < 8 mL.min-1.g-1
Compound 4 ended at the assay's limit (the forecaster's own chance of this, stated with the estimate: 50%); the middle value is on the limit's open side.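

On these data alone, in the Homo sapiens assay, putting 3-methylpyrazin-2-yl in place of the bicyclic group on the amide-type nitrogen gives an at least 1.4-fold lower number from compound 2 to compound 4 (0.16 log units; that floor lies within the scatter), so the size of this change remains unknown. Compound 4 gives a limit of the assay and not a number, and its step from compound 1, whose value is also a limit, cannot be read: the limit of < 8 mL.min-1.g-1 in the Homo sapiens assay, at which 2 of the 4 values shown sit. In a physicochemical assay for lipophilicity, using the shake flask method (on this read-out lower numbers stand for lower lipophilicity and higher numbers for higher lipophilicity), compound 2 gives 1.4 and compound 4 gives 0.3, a gap beyond the scatter, so this change is clearly resolved on that read-out.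

As far as these compounds go, with only these two compounds on the physicochemical assay, any link between the two read-outs stays open. Also open, from the compounds shown here alone, is how the Homo sapiens assay would respond to an amine or a carboxylic acid carried on the 3-methylpyrazin-2-yl group.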